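Cytotoxicity notes: carbamate to aryl amide on the core

The source may hold more compounds than are shown below. What is called first, only, known or untested is meant among the compounds shown, and "the series" means these compounds.

Compound 1 `CN(C)c1cc2[nH]c(C3CCCCC3)nc2cc1NC(=O)OCc1ccccc1` is the reference point of this series. In an ADME assay on Vero cells (Chlorocebus sabaeus) for cytotoxicity, read by resazurin assay, with a stated time of 3 days (on this read-out higher numbers stand for weaker inhibition and lower numbers for stronger inhibition), compound 1 returns > 100 ug/mL, which is a limit of the assay rather than a number. Compound 2 `CCCN(CCC)c1cc2[nH]c(C3CCCCC3)nc2cc1NC(=O)OCc1ccccc1` carries dipropylamino in place of dimethylamino on an aromatic carbon, and in this assay compound 2 returns > 100 ug/mL, again a limit. The step that the two limits leave unreadable from compound 1 to compound 2 therefore has no readable size. Compound 3 `C=Cc1cccc(C(=O)Nc2cc3nc(C4CCCCC4)[nH]c3cc2N(CC)CC)c1` gives > 100 ug/mL in this assay, also a limit. Among the compounds with values here, all three values sit at the limit of > 100 ug/mL in this assay, at which 3 of the 3 values shown sit, so compound 1 stands at the limit alongside the other two, and no step can be sized.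

Compound 4 `Cc1ccc(C(=O)Nc2cc3nc(C4CCCCC4)[nH]c3cc2N(C)C)cc1` differs from compound 1 by 4-methylphenyl in place of benzyloxy on a carbonyl carbon. Within the data shown here, no measured step bears directly on this change; the only step, from compound 1 to compound 2, is unreadable at both ends. Compound 3 shows that an aryl amide on the carbonyl carbon gave > 100 ug/mL, a limit. The step that the limit leaves unreadable from compound 1 to compound 4 is therefore expected to show no change beyond the scatter. Compound 4 is estimated at 150 ug/mL in this assay, within 60 ug/mL to 400 ug/mL, and is expected most likely to be reported as a limit again.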

Compound 4, half-maximal inhibitory concentration: > 100 ug/mL
Compound 4 ended at the assay's limit (the forecaster's own chance of this, stated with the estimate: 85%); the middle value is on the limit's open side.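

In this assay compound 4 returns > 100 ug/mL, a limit and not a number. No step can be read from compound 1 to compound 4, since both stand at the limit: the limit of > 100 ug/mL in this assay, at which 4 of the 4 values shown sit.

The compounds shown leave open whether any change on the shared core would give a measurable value in this assay.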